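A few compounds are considered here, and "the series" means these few. Any claim that something is new, unique, unknown or untested is made for them only; others in the source may bear on it.

Measured compounds:
compound 1, `COc1cccc(CNC(=O)c2nc(Br)c3cccnc3c2N[C@H]2CC[C@H](N)CC2)c1` — 6000 nM
compound 2, `N[C@H]1CC[C@H](Nc2c(C(=O)NCc3ccc(F)cc3)nc(N3CCCCC3)c3cccnc23)CC1` — > 10000 nM

Both were tested in a functional assay on SK-BR-3 cells (Homo sapiens) for cytotoxicity, read by MTT assay, with a stated time of 72 h; on this read-out higher numbers stand for weaker inhibition and lower numbers for stronger inhibition. Compound 1 gives 6000 nM in this assay, and this is the only result that is a plain number. Compound 2 reaches only a limit of the assay, (the limit of > 10000 nM in this assay, at which 1 of the 2 values shown sits), so no number is known for it. Compound 1 therefore stands alone as the reference point for what follows.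

Compound 3, `N[C@H]1CC[C@H](Nc2c(C(=O)NC3CCCCC3)nc(Br)c3cccnc23)CC1`, has not yet been measured in this assay. It differs from compound 1 in one place: cyclohexyl in place of 3-methoxybenzyl on an amide-type nitrogen. An aromatic group with one hydrogen-bond acceptor leaves, and a saturated carbon ring with none takes its place on the amide-type nitrogen.

For the measured compounds named here, no measured pair differing in one place is available, so there is no direct guide to how large this change will be. The step from compound 1 to compound 3 is expected to be a 1.5-fold higher number from compound 1 to compound 3 (0.18 log units; within the scatter), toward weaker inhibition, probably just beyond the usual scatter. Compound 3 is estimated at 9000 nM, within a range from 3000 nM to 27000 nM, with a fair chance that the assay reports only a limit.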

Compound 3, half-maximal inhibitory concentration: 4200 nM
Estimate against measurement, compound 3: 2.1-fold (0.33 log units) above; the range from low to high includes it.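

In this assay, putting cyclohexyl in place of 3-methoxybenzyl on the amide-type nitrogen gives a 1.4-fold lower number from compound 1 to compound 3 (0.15 log units; within the scatter). For the compounds shown here, this is the first comparison here between compounds that differ in one place, and it shows that an aromatic ring carrying one hydrogen-bond acceptor and a saturated carbon ring with none cannot be told apart in this cell read-out, even though the entering group has fewer heavy atoms. For this pair, then, neither the aromatic ring nor the methoxy oxygen makes a difference that rises above the ordinary spread of repeated measurements, and no separate measurement is available to offer an explanation for this result.

As far as these compounds go, what a very different group at the same place would do stays open, for instance a carboxylic acid, a primary amine or a longer alkyl chain on the amide-type nitrogen, any of which might or might not move the number beyond the scatter. A single pair also cannot tell whether exchanging 3-methoxybenzyl for cyclohexyl would read the same way on a different core.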